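Working notes: the step from compound 1 to compound 3

The compounds below may be only part of what the source reports. "The series", "measured", "known", "first", "only" and "open" are said of these compounds alone.

Of the compounds shown here, two have numbers so far in a functional assay on SH-SY5Y cells (Homo sapiens) for cytotoxicity, read by MTT assay, with a stated time of 72 h (on this read-out higher numbers stand for weaker inhibition and lower numbers for stronger inhibition), and they define the whole of the measured range. Compound 1 (`CC[S+]([O-])CCCCN=C=S`) gives 9810 nM in this test, and compound 2 (`[O-][S+](CCCCN=C=S)C1CCCC1`) gives 7140 nM under the same conditions. For the measured compounds named here, these two values lie within the usual scatter of each other, so compound 1 stands level with the only other measured compound and no ranking can be drawn.

Compound 3 (`[O-][S+](CCCCN=C=S)Cc1ccco1`) is not yet measured. Its change from compound 1 is furan-2-yl in place of methyl on a saturated chain carbon bound to a sulfur with furan-2-yl in place of methyl on a saturated chain carbon bound to a sulfur. Going by the values given here, no measured pair isolates this change, so the series offers no direct precedent. Among the compounds with values here, the only guide is the closeness of compound 1 at 9810 nM and compound 2 at 7140 nM in the data so far.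

In this assay no step beyond the scatter is expected, only a slight lean toward a lower number, and the estimated size is a 1.6-fold lower number from compound 1 to compound 3 (0.21 log units; within the scatter) for this change. For compound 3 the estimated value is 6000 nM with 2500 nM to 14000 nM as the expected range.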

Compound 3, half-maximal inhibitory concentration: 7790 nM
The estimate for compound 3 lay 1.3-fold (0.11 log units) below the measured number; the measured number falls inside the stated range.
By their numbers in this assay, from the lowest: compounds 2, 3 and 1 (each within the scatter of the next).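

For the compounds shown here, this is the first pair that isolates a single change at this place, and in this assay furan-2-yl in place of methyl on a saturated chain carbon bound to a sulfur gives a 1.3-fold lower number from compound 1 to compound 3 (0.10 log units; within the scatter) and so no step that can be read as real. The entering group brings five heavy atoms against one, a five-membered aromatic ring and a hydrogen-bond acceptor, yet this whole difference leaves the number within the usual scatter, so this change offers no basis for ranking compound 3 apart from compound 1. No supporting measurement bears on why the number stays level, and none is available to explain this step.

Still open, from the compounds shown here alone, is whether any group at this place can move the number beyond the scatter, for example phenyl, an amine or a carboxylic acid, since a single aromatic replacement cannot speak for these. A longer chain between the sulfur and the isothiocyanate is a separate open question, as the compounds shown all keep that part of the core of compound 1 unchanged.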